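The source may report more compounds than this note shows. Statements on the series, on what has been measured and on what is new or still open speak of the compounds shown alone.

Measured so far:
- compound 1 `COc1cccc(Cc2cc(C(C)C)nn(CC(=O)Nc3ccc(Br)cc3)c2=O)c1` gives > 50000 nM (a limit)
- compound 2 `COc1ccc(Cc2cc(-c3ccc(F)cc3)nn(CC(=O)Nc3ccc(Br)cc3)c2=O)cc1` gives > 50000 nM (a limit)
- compound 3 `Cc1cc(Cc2cccc(Cl)c2)c(=O)n(CC(=O)Nc2ccc(Br)cc2)n1` gives > 50000 nM (a limit)

In a functional assay on HL-60 cells (Homo sapiens), read by calcium flux (on this read-out higher numbers stand for an effect only at larger amounts of compound and lower numbers for an effect already at smaller amounts), compound 3 gives > 50000 nM as a limit of the assay, not as a number. For the measured compounds named here, the series so far shows the limit of > 50000 nM in this assay, at which 3 of the 3 values shown sit, and so no order among compound 1, compound 2 and compound 3 can be read from it. Going by the values given here, no pair of measured compounds differs in only one place, so there is no measured step to borrow.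

Compound 4 `Cc1cc(Cc2cccnc2)c(=O)n(CC(=O)Nc2ccc(Br)cc2)n1` keeps the rest of compound 3 and changes one group: pyridin-3-yl in place of 3-chlorophenyl on a saturated chain carbon bound to an aromatic carbon (the count reads pyridin-3-yl in place of 3-chlorophenyl on a saturated chain carbon bound to an aromatic carbon for this swap).

In this assay no step beyond the scatter is expected, in either direction, although a measurable effect cannot be ruled out. This expectation leans on compound 3 and its > 50000 nM as a limit, which leaves only a one-sided view. The estimate is a number no higher from compound 3 to compound 4 (the limit leaves the size open) (expected, not measured). For compound 4 the expected value is 50000 nM with an estimated range from 15000 nM to 50000 nM and most likely the assay will report only a limit.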

Compound 4, half-maximal effective concentration: > 50000 nM
Compound 4: only a limit was reported; the forecaster's own chance of this, stated with the estimate: 75%; the middle value sits exactly at the limit.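

Compound 3 and compound 4 both give only a limit in this assay, so no step can be read for pyridin-3-yl in place of 3-chlorophenyl, and the series still has no order: the limit of > 50000 nM in this assay, at which 4 of the 4 values shown sit. The compounds shown leave open which change to the shared core, if any, would give a value the assay can report as a number.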